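Fluoro to chloro on the long-chain member

The compounds below may be only part of what the source reports. "The series", "measured", "known", "first", "only" and "open" are said of these compounds alone.

In a functional assay on SW480 cells (Homo sapiens) for antiproliferative activity, read by MTT assay, with a stated time of 48 h (a lower number here means a stronger inhibitor, a higher number a weaker inhibitor), compound 1 (`CCCCC(CCO)n1cnc2c(Cl)nc(Cl)nc21`) gives 30900 nM, compound 2 (`CCCCCCCC(CCO)n1cnc2c(Cl)nc(Cl)nc21`) gives 13600 nM and compound 3 (`CCCCCCCCC(CCO)n1cnc2c(Cl)nc(F)nc21`) gives 15000 nM. Compound 3 lies within the scatter of compound 2, and the value of compound 1 is higher than both.

Compound 4 (`CCCCCCCCC(CCO)n1cnc2c(Cl)nc(Cl)nc21`) differs from compound 3 by chloro in place of fluoro on an aromatic carbon, between two ring nitrogen atoms. Within the data shown here, no measured step isolates this swap. Among the measured compounds shown here, the only measured step, a 2.3-fold lower number from compound 1 to compound 2 (0.36 log units; beyond the scatter), is modest and concerns propyl in place of hydrogen on the chain, not the halogen. No change beyond the scatter is therefore expected, and the expected step is a 1.3-fold lower number from compound 3 to compound 4 (0.10 log units; within the scatter). Compound 4 is estimated at 12000 nM, with an expected range of 6000 nM to 25000 nM.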

Compound 4, half-maximal inhibitory concentration: 24000 nM
The estimate for compound 4 lay 2.0-fold (0.30 log units) below the measured number; the measured number falls inside the stated range.
By their numbers in this assay, from the lowest: compounds 2, 3, 4 and 1 (each within the scatter of the next, the first and the last beyond it).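

In this assay, the halogen swap on the aromatic carbon between two ring nitrogen atoms now has a direct reading: a 1.6-fold higher number from compound 3 to compound 4 (0.20 log units; within the scatter), so chloro and fluoro are not separated here. The chain steps read alike, with a 1.8-fold higher number from compound 2 to compound 4 (0.25 log units; within the scatter) and a 1.3-fold lower number from compound 1 to compound 4 (0.11 log units; within the scatter), so the step beyond the scatter seen for compound 2 does not carry over to compound 4 as a steady chain-length trend. Nothing available bears on a cause for these results.

Going by these compounds, whether an amine or a methoxy group at this position, or a longer chain, would give a change beyond the scatter remains open.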